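Phenol methylation in a dihydrofolate reductase series

This account rests on a few compounds, and the source may have more. Where it says the series, first, only, none or still open, it means among the compounds named here.

Compound 1 `COc1cc(Cc2cnc(N)nc2N)cc(CCC(=O)N2N=Cc3ccccc3C2C)c1OC` and compound 2 `COc1cc(Cc2cnc(N)nc2N)cc(/C=C/C(=O)N2N=Cc3ccccc3C2c2ccc(CO)cc2)c1O` both carry the shared core attached to a larger amide-bearing portion. In an assay on isolated protein for inhibition of Dihydrofolate reductase (Homo sapiens) (on this read-out lower numbers stand for stronger inhibition and higher numbers for weaker inhibition), compound 1 gives > 28000 nM, which is a limit of this assay and not a number. In this assay compound 2 gives > 24000 nM, likewise a limit rather than a number (the limit of > 24000 nM in this assay, at which 1 of the 2 values shown sits). Compound 2 therefore stands at the limit, with both values shown being limits and no measurable inhibition recorded for it. Compound 3 `COc1cc(Cc2cnc(N)nc2N)cc(/C=C/C(=O)N2N=Cc3ccccc3C2c2ccc(CO)cc2)c1OC` differs from compound 2 by methyl in place of hydrogen on an oxygen on an aromatic ring, hydroxy to methoxy. Compound 1 carries the same methoxy pattern and also stands at a limit (the limit of > 28000 nM in this assay, at which 1 of the 2 values shown sits). No step beyond the scatter is expected for a step that the limit leaves unreadable from compound 2 to compound 3. Compound 3 is accordingly expected to give 30000 nM, within 8000 nM to 100000 nM, most probably reported again only as a limit.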

Compound 3, half-maximal inhibitory concentration: > 23000 nM
Compound 3: no number, only a limit; the forecaster's own chance of this, stated with the estimate: 85%; the middle value lies beyond the limit too.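

In this assay compound 2 gives > 24000 nM, a limit and not a number. For the compounds shown here, compound 3 gives > 23000 nM, also a limit, so no step from compound 2 to compound 3 can be read. The compounds shown leave open whether hydroxy to methoxy changes inhibition at all.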